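This account rests on a few compounds, and the source may have more. Where it says the series, first, only, none or still open, it means among the compounds named here.

Of the compounds shown here, three that share one core have been measured in a physicochemical assay for lipophilicity, using the shake flask method, in phosphate buffer, measured as octanol-water partition, with a stated time of 85 min, at pH 7.4; on this read-out higher numbers stand for higher lipophilicity and lower numbers for lower lipophilicity. Compound 1 `O=Cc1ccc(-c2cn3ccnc3c(-c3ccc4ncn(C5CCCCC5)c4c3)n2)cc1` gives 1.5. Compound 2 `c1ccc2c(-c3cn4ccnc4c(-c4ccc5ncn(C6CCCCC6)c5c4)n3)cccc2c1` gives 1.44. Compound 3 `c1cn2cc(-c3ccsc3)nc(-c3ccc4ncn(C5CCCCC5)c4c3)c2n1` gives 1.81. Compound 2 stands at the lowest of the three numbers; its nearest neighbour is compound 1, and the step of a number 0.06 log units lower from compound 1 to compound 2 (within the scatter) lies within the scatter, whereas the step of a number 0.37 log units higher from compound 2 to compound 3 (beyond the scatter) lies beyond it. The third pairing, a number 0.31 log units higher from compound 1 to compound 3 (beyond the scatter), also lies beyond the scatter.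

Compound 4 `c1ccc(Cn2cnc3ccc(-c4nc(-c5cccc6ccccc56)cn5ccnc45)cc32)cc1` has not yet been measured. It differs from compound 2 in one place: benzyl in place of cyclohexyl on an aromatic nitrogen. None of the three measured steps touches this part of the core; each of them exchanges the other aromatic group, and the largest of them, a number 0.37 log units higher from compound 2 to compound 3 (beyond the scatter), was modest. So the measured steps give no direct guide to this change, and only the observation that the steps seen so far stayed modest carries over. For compound 4 in this assay the estimate is therefore a small downward step, a number 0.29 log units lower from compound 2 to compound 4 (within the scatter), with no strong claim on its size. Compound 4 is expected to give about 1.15, most likely between 0.75 and 1.55.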

Compound 4, partition coefficient: 2
Compound 4: middle estimate off by 0.85 log units, on the low side; the measured number lies above the stated range.
By their numbers in this assay, from the lowest: compounds 2 and 1 (each within the scatter of the next); then compounds 3 and 4 (each within the scatter of the next).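

In this assay, going by these compounds alone, the change of benzyl in place of cyclohexyl on an aromatic nitrogen gives a number 0.56 log units higher from compound 2 to compound 4 (beyond the scatter), so this position, which no earlier step touched, can also shift the number beyond the scatter. The change itself is small on paper: the entering group has one more heavy atom, both groups are carbon only with no hydrogen-bond donors or acceptors and no net charge, and a six-membered non-aromatic ring gives way to a six-membered aromatic one. Nothing available here gives a measured reason for this upward step.

With a single pair at this position, the compounds shown cannot separate the effect of the extra carbon from that of the aromatic ring, and a phenyl group placed directly on the nitrogen, a longer chain such as phenethyl, or a benzyl carrying an amine or a carboxylic acid would help to tell these apart. Going by these compounds, it also remains open whether the same exchange gives a similar step when thiophen-3-yl or 4-formylphenyl replaces naphthalen-1-yl on the other side of the shared core.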